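The compounds below may be only part of what the source reports. "The series", "measured", "known", "first", "only" and "open" are said of these compounds alone.

The series shares one core: compound 1 `Cc1ccccc1C(=O)NC(CCN(C)C)c1ccc(Cl)cc1`, compound 2 `Cc1ccc(C(=O)NC(CCN(C)C)c2ccc(Cl)cc2)c(C)c1` and compound 3 `COc1ccc(NC(=O)NC(CCN(C)C)c2ccc(Cl)cc2)cc1` differ only in the group carried on the amide or urea side. Going by the values given here, in an assay on NIH3T3 cells with Urotensin-2 receptor (Homo sapiens) as the target (on this read-out higher numbers stand for an effect only at larger amounts of compound and lower numbers for an effect already at smaller amounts), compound 1 gives 3550 nM, while compound 2 gives 1550 nM, so that the step of a 2.3-fold lower number from compound 1 to compound 2 (0.36 log units; beyond the scatter) stands out as the only change so far beyond the scatter. Compound 3 gives 2000 nM, a number that sits between those of compound 2 and compound 1 and lies within the scatter of both, so nothing separates compound 3 from either neighbour.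

Compound 4 `CN(C)CCC(NC(=O)NCc1ccccc1)c1ccc(Cl)cc1` has not yet been measured. Relative to compound 3 the change is benzyl in place of 4-methoxyphenyl on an amide-type nitrogen. Among the compounds with values here, no measured step touches this part of the molecule: the one step seen, methyl in place of hydrogen on an aromatic carbon of the acyl group, concerns a different position and a different kind of change, and it was itself modest. With nothing closer to lean on, the expected step of no change at the digits printed from compound 3 to compound 4 (within the scatter) is none beyond the scatter in either direction, and a broad range is warranted. Compound 4 is therefore estimated at 2000 nM in this assay, with a range from 600 nM to 7000 nM.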

Compound 4, half-maximal effective concentration: 2000 nM
Compound 4: the middle estimate sits on the measured number at the digits printed; the range from low to high includes it.
By their numbers in this assay, from the lowest: compounds 2, 3, 4 and 1 (each within the scatter of the next, the first and the last beyond it).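

Going by these compounds alone, on the amide-type nitrogen, benzyl in place of 4-methoxyphenyl gives no change at the digits printed from compound 3 to compound 4 (within the scatter) in this assay, the first reading at this position, and the loss of the oxygen and its hydrogen-bond acceptor, together with the change in how the aromatic ring is attached, leaves no difference that can be told from the scatter. At the carbonyl carbon, benzylamino in place of 2,4-dimethylphenyl gives a 1.3-fold higher number from compound 2 to compound 4 (0.11 log units; within the scatter), and benzylamino in place of 2-methylphenyl gives a 1.8-fold lower number from compound 1 to compound 4 (0.25 log units; within the scatter), so neither exchange of the aryl group for this urea side chain separates the compounds, even though compound 1 and compound 2 are themselves separated by a step beyond the scatter. No supporting data bear on this result, and what lies behind it remains unexplained.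

The compounds shown leave open whether this flat reading would hold for a longer chain on the nitrogen, such as phenethyl, or for a small alkyl group such as methyl with no aromatic ring at all. They also leave open what 4-methoxybenzyl would give, or a benzyl ring carrying a carboxylic acid or an amine.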